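The compounds below may be only part of what the source reports. "The series", "measured", "known", "first", "only" and "open" are said of these compounds alone.

Measured in a functional assay on K562 cells (Homo sapiens) for antiproliferative activity, read by CellTiter-Glo and CCK-8 assay, with a stated time of 72 h; a higher number here means a weaker inhibitor of growth, a lower number a stronger inhibitor of growth:
compound 1, `CNc1nc(Nc2ccc(C)c([N+](=O)[O-])c2)ncc1C(=O)Nc1cc(NC(=O)c2cccc(OC)c2)ccc1C`, 480 nM
compound 2, `CNc1nc(Nc2ccc(C)c([N+](=O)[O-])c2)ncc1C(=O)Nc1cc(NC(=O)c2ccc(OC)c(OC)c2)ccc1C`, 680 nM
compound 3, `CNc1nc(Nc2ccc(C)c(N)c2)ncc1C(=O)Nc1cc(NC(=O)c2cc(OC)cc(OC)c2)ccc1C`, 230 nM

Compound 1 and compound 2 share one core; the change between them is methoxy in place of hydrogen on an aromatic carbon and it gave a 1.4-fold higher number from compound 1 to compound 2 (0.15 log units; within the scatter). Compound 3 carries a different core, and how the two cores differ is not broken down here. In this assay compound 3 gives the lowest of the three numbers, beyond the scatter from both compound 1 and compound 2.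

Compound 4, `CNc1nc(Nc2ccc(C)c(N)c2)ncc1C(=O)Nc1cc(NC(=O)c2cc(OC)c(OC)c(OC)c2)ccc1C`, has yet to be measured in this assay. It differs from compound 3 by methoxy in place of hydrogen on an aromatic carbon. Among the measured compounds shown here, this is the same kind of change as the one from compound 1 to compound 2, not the same one: here the entering methoxy sits ortho to two methoxy groups, there ortho to a methoxy group. The step from compound 3 to compound 4 is expected to be small, a 1.3-fold higher number from compound 3 to compound 4 (0.12 log units; within the scatter), resting on the earlier step of a 1.4-fold higher number from compound 1 to compound 2 (0.15 log units; within the scatter), which lay within the scatter. Compound 4 is estimated at 300 nM, expected to fall between 150 nM and 650 nM.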

Compound 4, concentration for 50% growth inhibition: 250 nM
The estimate for compound 4 lay 1.2-fold (0.08 log units) above the measured number; the range from low to high includes it.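

In this assay, going from 3,5-dimethoxyphenyl to 3,4,5-trimethoxyphenyl gave a 1.1-fold higher number from compound 3 to compound 4 (0.04 log units; within the scatter). Set beside the earlier methoxy step, this result gives no sign that the size of the step depends on the core: the same change on two cores in this assay, a 1.4-fold higher number (0.15 log units; within the scatter) from compound 1 to compound 2 and a 1.1-fold higher number (0.04 log units; within the scatter) from compound 3 to compound 4, 1.3-fold (0.12 log units) apart, within the scatter of two such steps. Among the compounds shown here, that agreement rests on only two pairs, with the entering methoxy ortho to a methoxy group in one and ortho to two methoxy groups in the other, so it does not show that this change stays small on other cores or at other places on the ring.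

No pair shown has the same aromatic amide on both cores, so what the difference between the cores does to the number remains open. Also open, going by these compounds, is whether a group other than methoxy at the place filled in compound 4, such as a hydroxyl, a chlorine or a longer ethoxy chain, would give a step beyond the scatter.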